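The source may hold more compounds than are shown below. What is called first, only, known or untested is meant among the compounds shown, and "the series" means these compounds.

Measured compounds in an assay on isolated protein for inhibition of protein deacetylase HDAC6 (Homo sapiens), read by fluorescence, with stated times of 5 min and 60 min; on this read-out higher numbers stand for weaker inhibition and lower numbers for stronger inhibition:
compound 1 `Cc1ccc(CN2C(=O)N(c3ccc(Cl)cc3)C(=O)C2CCC(=O)Nc2ccc(C(=O)NO)cc2)cc1` gives 4.4 nM
compound 2 `CCCN1C(=O)N(c2ccc(Cl)cc2)C(=O)C1CCC(=O)Nc1ccc(C(=O)NO)cc1` gives 12.6 nM
compound 3 `Cc1ccc(CN2C(=O)N(C3CCCCC3)C(=O)C2CCC(=O)Nc2ccc(C(=O)NO)cc2)cc1` gives 10.3 nM

Compound 3 stands second highest of the three numbers. Its gap to compound 2 lies within the scatter, so no order between these two is claimed. Against compound 1 the step of a 2.3-fold higher number from compound 1 to compound 3 (0.37 log units; beyond the scatter) is beyond the scatter.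

Compound 4 `CCCN1C(=O)N(C2CCCCC2)C(=O)C1CCC(=O)Nc1ccc(C(=O)NO)cc1` has not been measured. It differs from compound 3 in one place: ethyl in place of 4-methylphenyl on a saturated chain carbon bound to an amide-type nitrogen in a ring. The shared core, with the hydroxamic acid side chain, is untouched.

Among the compounds with values here, one measured step bears directly on this change, made on the core carrying 4-chlorophenyl rather than cyclohexyl on the amide-type nitrogen in the ring: a 2.9-fold higher number from compound 1 to compound 2 (0.46 log units; beyond the scatter). That step is modest but beyond the scatter. Within the data shown here, whether the change carries over onto the cyclohexyl core cannot be checked from the data; only this single step exists. Taking it as the best guide, a modest rise in the number from compound 3 is expected, in the same direction and of about the same size.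

Compound 4 is therefore expected to give 30 nM, with a range from 12 nM to 75 nM. For compound 4 the expected step is a 2.9-fold higher number from compound 3 to compound 4 (0.46 log units; beyond the scatter).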

Compound 4, half-maximal inhibitory concentration: > 40 nM
Compound 4 gave a limit, no number; the forecaster's own chance of this, stated with the estimate: 2%; middle value at least 1.3-fold (0.12 log units) from the limit.
By their numbers in this assay, from the lowest: compound 1; then compounds 3 and 2 (each within the scatter of the next). At a limit, above all of these: compound 4.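

In this assay the change from 4-methylphenyl to ethyl on a saturated chain carbon bound to an amide-type nitrogen in a ring now has a second reading, an at least 3.8-fold higher number from compound 3 to compound 4 (0.58 log units; beyond the scatter), so the number rises on both cores shown: the same change on two cores in this assay, a 2.9-fold higher number (0.46 log units; beyond the scatter) from compound 1 to compound 2 and an at least 3.8-fold higher number (0.58 log units; beyond the scatter) from compound 3 to compound 4; the limit leaves it open whether they differ The change from 4-chlorophenyl to cyclohexyl on an amide-type nitrogen in a ring also has a second reading, an at least 3.1-fold higher number from compound 2 to compound 4 (0.50 log units; beyond the scatter), and again the number rises: the same change on two cores in this assay, a 2.3-fold higher number (0.37 log units; beyond the scatter) from compound 1 to compound 3 and an at least 3.1-fold higher number (0.50 log units; beyond the scatter) from compound 2 to compound 4; the limit leaves it open whether they differ For compound 4 the value > 40 nM is a limit and not a number, so both new steps have a lower bound but no upper one: the limit of > 40 nM in this assay, at which 1 of the 4 values shown sits.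

Still open, as far as these compounds go, is whether either change costs more on one core than on the other, and whether compound 4 lies within the scatter of anything beyond the pairs with printed steps. Also open, from the compounds shown here alone, is how much of the 4-methylbenzyl to propyl difference follows the aromatic ring and how much the chain, a question that benzyl, cyclohexylmethyl or a longer chain such as hexyl at this place would help to separate.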